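The compounds below may be only part of what the source reports. "The series", "measured", "known", "first", "only" and "open" are said of these compounds alone.

In a functional assay on MDA-MB-231 cells (Homo sapiens) for antiproliferative activity, with a stated time of 5 days (on this read-out higher numbers stand for weaker inhibition and lower numbers for stronger inhibition), compound 1 (`COc1ccc(-n2nc(-c3ccc4ccccc4c3)nc2N2C(=O)COC23C=CC(=O)C=C3)cc1`) gives 60 nM and compound 2 (`COc1ccc(-n2nc(-c3ccc4ccccc4c3)nc2N2C(=O)C(C)OC23C=CC(=O)C=C3)cc1`) gives 50 nM, so compound 1 has a single measured neighbour and lies within the scatter of it. Compound 3 (`O=C1C=CC2(C=C1)OCC(=O)N2c1nc(-c2ccc3ccccc3c2)nn1-c1ccc(C(F)(F)F)cc1`) keeps the core of compound 1 and exchanges one group: trifluoromethyl in place of methoxy on an aromatic carbon (trifluoromethyl in place of methoxy on an aromatic carbon, para to a large group). Going by the values given here, the only measured step, a 1.2-fold lower number from compound 1 to compound 2 (0.08 log units; within the scatter), is methyl in place of hydrogen on a saturated ring carbon, a different place and a different kind of change, so it gives little guidance here. Among the compounds with values here, no measured pair tests this aromatic position, so the estimate starts from compound 1 at 60 nM and expects a modest move toward a higher number in this assay, though a result within the scatter would fit as well. The expected step is a 1.5-fold higher number from compound 1 to compound 3 (0.18 log units; within the scatter) in size. For compound 3 the estimated value is 90 nM, with an expected range from 30 nM to 300 nM.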

Compound 3, half-maximal inhibitory concentration: 70 nM
Beside the measured number, compound 3's estimate is 1.3-fold (0.11 log units) above it, and the stated range covers the measured number.
By their numbers in this assay, from the lowest: compounds 2, 1 and 3 (each within the scatter of the next).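

Going by these compounds alone, this pair is the first measured test of the aromatic position: in this assay, trifluoromethyl in place of methoxy gives a 1.2-fold higher number from compound 1 to compound 3 (0.07 log units; within the scatter) and so no change that can be told apart from ordinary variation between repeats. On this single pair, the 4-methoxyphenyl and 4-(trifluoromethyl)phenyl groups read alike, which shows that the methoxy oxygen is not needed to keep the number in this range. The data shown offer no measurement that could explain this result.

Still open, as far as these compounds go, is how an amine, a carboxylic acid or a longer chain such as butoxy would read at this place on the shared core. Also open, from the compounds shown here alone, is whether trifluoromethyl would read the same on the core that carries the added methyl of compound 2.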